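Replacing a Thioether Link with a Hydroxymethyl Link

The source may report more compounds than this note shows. Statements on the series, on what has been measured and on what is new or still open speak of the compounds shown alone.

Compound 1 `COc1ccc(-c2nc(CSc3cccc(Br)c3)nc3ccsc23)cn1` was examined in an ADME assay on cells (Homo sapiens) for cytotoxicity, read by resazurin assay, with a stated time of 5 days; on this read-out higher numbers stand for lower toxicity in this test and lower numbers for higher toxicity in this test. In this assay compound 1 gives only a limit, > 50000 nM, and not a number. Compound 2 `COc1ccc(-c2nc(C(C)(C)S(=O)(=O)c3cccc(Cl)c3)nc3ccsc23)cn1` likewise reaches only a limit in this assay, > 50000 nM. Compound 3 `O=S(=O)(Cc1nc(-c2ccc(Cl)nc2)c2sccc2n1)c1cccc(Cl)c1` gives 70000 nM in this assay. Compound 1 therefore stands at the limit of > 50000 nM in this assay, at which 2 of the 3 values shown sit, alongside most of the values shown. Compound 4 `COc1ccc(-c2nc(CC(O)c3cccc(Cl)c3)nc3ccsc23)cn1` has not yet been measured; it differs from compound 1 by (3-chlorophenyl)(hydroxy)methyl in place of (3-bromophenyl)sulfanyl on a saturated chain carbon bound to an aromatic carbon. Within the data shown here, no measured pair of compounds shows what such a change does in this assay. The step that the limit leaves unreadable from compound 1 to compound 4 is expected to stay within the usual scatter, with no direction beyond it. Compound 4 is estimated at 60000 nM, with a range from 25000 nM to 150000 nM.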

Compound 4, half-maximal cytotoxic concentration: 31000 nM
Compound 4: middle estimate off by 1.9-fold (0.29 log units), on the high side; low and high end bracket the measured number.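

Compound 4 is the first compound shown to carry a hydrogen-bond donor in this group, and in this assay the change gives an at least 1.6-fold lower number from compound 1 to compound 4 (0.20 log units; that floor lies within the scatter). This step is a floor and not a full size, because compound 1 sits at a limit of the assay: the limit of > 50000 nM in this assay, at which 2 of the 4 values shown sit. So the change brings no step beyond the usual scatter that can be read here. The compounds shown leave open how much of the step comes from chlorine replacing bromine and how much from the new link, and what an amine in place of the hydroxy group would do.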